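The compounds below may be only part of what the source reports. "The series", "measured", "known", "first", "only" and "open" are said of these compounds alone.

Measured compounds in an ADME assay on microsomes from liver (Mus musculus) for metabolic stability; a lower number here means slower removal, a higher number faster removal of the compound:
- compound 1, `NC(=O)CNC(=O)C[C@H]1CC[C@]2(CC1)OO[C@]1(O2)C2CC3CC(C2)CC1C3`, gives 5.6 uL/min
- compound 2, `NCCNC(=O)C[C@H]1CC[C@]2(CC1)OO[C@]1(O2)C2CC3CC(C2)CC1C3`, gives 10.8 uL/min
- compound 3, `NC(=O)CNC(=O)C[C@@H]1CCC[C@]2(C1)OOC1(O2)C2CC3CC(C2)CC1C3`, gives 18.6 uL/min

Compounds 1 and 2 share one core; compound 3 is built on another, and the difference between the two cores is not broken down here. Within the first pair the change is aminomethyl in place of carbamoyl on a saturated chain carbon bound to an amide-type nitrogen; it gave a 1.9-fold higher number from compound 1 to compound 2 (0.29 log units; within the scatter). Compound 3 gives the highest of the three numbers: its gap to compound 1 lies beyond the scatter, its gap to compound 2 within it.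

Compound 4, `NCCNC(=O)C[C@@H]1CCC[C@]2(C1)OOC1(O2)C2CC3CC(C2)CC1C3`, is not yet measured. It differs from compound 3 by aminomethyl in place of carbamoyl on a saturated chain carbon bound to an amide-type nitrogen, the same change as between compound 1 and compound 2, at the same place. Within the data shown here, the step is expected to be a 1.7-fold higher number from compound 3 to compound 4 (0.24 log units; within the scatter), resting on the one earlier example of this change, a 1.9-fold higher number from compound 1 to compound 2 (0.29 log units; within the scatter). Since that single earlier step lay within the scatter, the expectation carries wide bounds. Compound 4 is expected to give 32 uL/min, with an expected range from 16 uL/min to 60 uL/min.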

Compound 4, intrinsic clearance in a liver preparation (reported as CLH), per the amount of preparation that the assay uses: 8.2 uL/min
Compound 4: middle estimate off by 3.9-fold (0.59 log units), on the high side, and the stated range ends above it.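

On the core of compound 3, aminomethyl in place of carbamoyl gives a 2.3-fold lower number from compound 3 to compound 4 (0.36 log units; beyond the scatter) in this assay. Set beside the earlier example, the same change does not carry over from one core to the other as a fixed step: the same change on two cores in this assay, a 1.9-fold higher number (0.29 log units; within the scatter) from compound 1 to compound 2 and a 2.3-fold lower number (0.36 log units; beyond the scatter) from compound 3 to compound 4, 4.4-fold (0.64 log units) apart, beyond the scatter of two such steps

Among these compounds, this shows that, in this series, the step measured on the core of compound 1 was not a safe guide to the step on the core of compound 3; it does not show why the two cores differ, and with only two pairs, one of them within the scatter, it gives no rule for any further core.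

The compounds shown leave open whether this dependence on the core also holds for other groups at this place on the chain, such as a carboxylic acid, a hydroxyl or a longer chain ending in an amine. Also open, from the compounds shown here alone, is which part of the difference between the two cores goes with the change in step.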